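From phenyl to 4-methoxyphenyl at the assay limit

The source may report more compounds than this note shows. Statements on the series, on what has been measured and on what is new or still open speak of the compounds shown alone.

Measured in an ADME assay on MCF-10A cells (Homo sapiens) for cytotoxicity, read by MTT assay, with a stated time of 48 h; a higher number here means a weaker inhibitor, a lower number a stronger inhibitor:
Compound 1 `COc1cc(C#N)ccc1OCc1nnc(-c2ccc(C)cc2)o1`: > 100000 nM
Compound 2 `COc1cc(C#N)ccc1OCc1nnc(-c2ccc(F)cc2)o1`: > 100000 nM
Compound 3 `N#Cc1ccc(OCc2nnc(-c3ccccc3)o2)cc1F`: > 100000 nM

Each of these values is a limit of the assay and not a number. Compound 3 therefore gives no exact starting point.

Compound 4 `COc1ccc(-c2nnc(COc3ccc(C#N)c(F)c3)o2)cc1` has not yet been measured. It carries methoxy in place of hydrogen on an aromatic carbon.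

Among the compounds with values here, the only measured step between two compounds is a step that the two limits leave unreadable from compound 1 to compound 2, with fluoro in place of methyl on an aromatic carbon. It offers no size or direction to carry over, so no step beyond the usual scatter is expected. The expected change is a number no higher from compound 3 to compound 4 (the limit leaves the size open). For compound 4 the estimated value is 100000 nM, with an expected range from 40000 nM to 250000 nM.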

Compound 4, half-maximal inhibitory concentration: > 100000 nM
Compound 4 ended at the assay's limit (the forecaster's own chance of this, stated with the estimate: 80%); the middle value sits exactly at the limit.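

No step from compound 3 to compound 4 can be read, because both values are limits of the assay and not numbers: the limit of > 100000 nM in this assay, at which 4 of the 4 values shown sit.

The compounds shown leave open whether methoxy in place of hydrogen changes the result in this assay at all.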